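A few compounds are considered here, and "the series" means these few. Any claim that something is new, unique, unknown or untested is made for them only; others in the source may bear on it.

Series notes. In an ADME assay on SW480 cells (Homo sapiens) for cytotoxicity, read by MTT assay, with a stated time of 72 h (on this read-out higher numbers stand for weaker inhibition and lower numbers for stronger inhibition), compound 1 `O=C(Nc1cccc(F)c1)c1cccc(/C=C2\CC(=O)N(c3ccccc3)C2=O)c1` returns only a limit, > 100000 nM, not a number. Among the measured compounds shown here, compound 2 `CSc1cccc(NC(=O)c2cccc(/C=C3\CC(=O)N(c4ccccc4)C3=O)c2)c1` gives 74300 nM in this assay, the only number among the values shown. For the measured compounds named here, the step of an at least 1.3-fold lower number from compound 1 to compound 2 (0.12 log units; that floor lies within the scatter) is the one measured change bearing on the move to compound 3 `O=C(Nc1ccc(F)cc1)c1cccc(/C=C2\CC(=O)N(c3ccccc3)C2=O)c1`, which puts (4-fluorophenyl in place of 3-(methylsulfanyl)phenyl on an amide-type nitrogen). A step of similar size, toward higher numbers or none beyond the scatter, is expected, as a 1.3-fold higher number from compound 2 to compound 3 (0.13 log units; within the scatter). Compound 3 is estimated at 100000 nM in this assay, within 50000 nM to 200000 nM, with a fair chance that only a limit is reported.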

Compound 3, half-maximal inhibitory concentration: > 100000 nM
Compound 3 gave a limit, no number; the forecaster's own chance of this, stated with the estimate: 50%; the middle value lies on the limit itself.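

In this assay, 4-fluorophenyl in place of 3-(methylsulfanyl)phenyl on the amide-type nitrogen gives an at least 1.3-fold higher number from compound 2 to compound 3 (0.12 log units; that floor lies within the scatter), so this change is not shown to move the read-out beyond the scatter. The step between the 3-fluorophenyl and 4-fluorophenyl compounds cannot be read, as both values are limits. Compound 2 therefore remains the only compound with a number, and the read-out has little room to separate these compounds: the limit of > 100000 nM in this assay, at which 2 of the 3 values shown sit.

Still open, from the compounds shown here alone, is how an amine or a carboxylic acid in place of the methylsulfanyl would read. The effect of fluoro placement on this ring also remains unresolved.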